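This account rests on a few compounds, and the source may have more. Where it says the series, first, only, none or still open, it means among the compounds named here.

Measured so far in a physicochemical assay for lipophilicity; on this read-out higher numbers stand for higher lipophilicity and lower numbers for lower lipophilicity:
- compound 1 `CCn1cnc2c(-c3ccc(F)c(Oc4cccc(S(=O)(=O)CC)c4)c3)cnnc21`: 2.3
- compound 2 `CC(C)n1cnc2c(-c3ccc(F)c(Oc4ccc(C#N)cn4)c3)cnnc21`: 2.7
- compound 3 `CCn1cnc2c(-c3ccc(F)c(-c4ccc(S(C)(=O)=O)cc4OC)c3)cnnc21`: 2.5

No two of these compounds differ in one place only, so the data hold no direct example of what a single change does. Compound 3 stands at 2.5. Compound 1 at 2.3 lies within the usual scatter of it, and so does compound 2 at 2.7. On this assay, then, compound 3 cannot be firmly ranked against either of them.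

The next compound to be measured is compound 4 `CCn1cnc2c(-c3ccc(F)c(-c4ccc(S(=O)(=O)C(C)C)cc4OC)c3)cnnc21`. It keeps all of compound 3 except one group: isopropyl in place of methyl on a sulfonyl sulfur. In plain words, this is isopropyl in place of methyl on a sulfonyl sulfur, so methylsulfonyl becomes isopropylsulfonyl. The change adds no ring and no net charge.

For the measured compounds named here, with no measured step as a guide, the expectation rests on the structural change and on the starting point of compound 3 at 2.5. A moderate rise on this assay is expected, large enough to stand clear of the usual scatter. The expected size is a number 0.60 log units higher from compound 3 to compound 4 (beyond the scatter). For compound 4 the estimated value is 3.1, with an expected range from 2.8 to 3.5.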

Compound 4, distribution coefficient: 3
Estimate against measurement, compound 4: 0.10 log units above, and the stated range covers the measured number.
By their numbers in this assay, from the lowest: compounds 1, 3, 2 and 4 (each within the scatter of the next, the first and the last beyond it).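

For the compounds shown here, until now no pair in this set differed in one place only, so the effect of a single change could not be seen. Going by these compounds alone, with the rest of the molecule held constant, this assay now gives a first direct reading for isopropyl in place of methyl on a sulfonyl sulfur, a number 0.50 log units higher from compound 3 to compound 4 (beyond the scatter), which shows that the read-out responds to a change at this position. The change brings 3 carbon atoms in place of 1 and adds no ring, no hydrogen-bond donor or acceptor and no net charge, but nothing available accounts for the size of the step, which stands as one observation from a single pair.

Still open, on these data alone, is how the read-out would respond to other groups on the same sulfur, such as a longer chain like n-butyl, a cyclopropyl ring or an amine. Also open, as far as these compounds go, is whether the same swap would give a step of similar size on a different core, such as that of compound 1, whose sulfonyl sulfur carries ethyl.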